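Swapping the hydrazone substituent on a shared adenosine core

This account rests on a few compounds, and the source may have more. Where it says the series, first, only, none or still open, it means among the compounds named here.

Of the compounds shown here, three on one core have been measured in an assay on CHO-K1 cells for displacement of a labelled ligand from adenosine receptor A1 (Homo sapiens), read by scintillation counting, with a stated time of 60 min; a lower number here means a stronger inhibitor, a higher number a weaker inhibitor. Compound 1 `CCCCC/C=C/C=C/C=N/Nc1nc(N)c2ncn([C@@H]3O[C@H](CO)[C@@H](O)[C@H]3O)c2n1` gives 2 nM. Compound 3 `N#Cc1ccccc1/C=N/Nc1nc(N)c2ncn([C@@H]3O[C@H](CO)[C@@H](O)[C@H]3O)c2n1` gives 2.9 nM, the highest of the two numbers, yet a 1.5-fold higher number from compound 1 to compound 3 (0.16 log units; within the scatter). Compound 2 `CSCC/C=N/Nc1nc(N)c2ncn([C@@H]3O[C@H](CO)[C@@H](O)[C@H]3O)c2n1` gives only a limit of the assay, > 10000 nM; this is the limit of > 10000 nM in this assay, at which 1 of the 3 values shown sits.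

The step now followed leads to compound 4 `Nc1nc(N/N=C/C2CCCC2)nc2c1ncn2[C@@H]1O[C@H](CO)[C@@H](O)[C@H]1O`, which is not yet measured. Its change from compound 3 is cyclopentyl in place of 2-cyanophenyl on a carbon with a double bond to nitrogen.

Among the compounds with values here, two measured steps bear on this change, both at the same carbon. When a non-ring chain replaced the nine-carbon chain, an at least 5000-fold higher number from compound 1 to compound 2 (3.69 log units; beyond the scatter). When the 2-cyanophenyl group replaced that chain, an at least 3400-fold lower number from compound 2 to compound 3 (3.53 log units; beyond the scatter). Cyclopentyl, a ring but not an aromatic one and without the nitrile, sits between those cases; the hydrogen-bond acceptor of compound 3 leaves with it. A higher number than compound 3 is therefore expected, though smaller than the loss seen for compound 2.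

Compound 4 is estimated at 400 nM in this assay, within a range of 40 nM to 6000 nM. The expected step is a 140-fold higher number from compound 3 to compound 4 (2.14 log units; beyond the scatter).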

Compound 4, inhibition constant: 5.6 nM
Compound 4: the middle estimate sits 71-fold (1.85 log units) above what was measured; measured number below the stated range.
By their numbers in this assay, from the lowest: compounds 1, 3 and 4 (each within the scatter of the next, the first and the last beyond it). At a limit, above all of these: compound 2.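

Cyclopentyl in place of 2-cyanophenyl gives a 1.9-fold higher number from compound 3 to compound 4 (0.29 log units; within the scatter), so in this assay neither the six-membered aromatic ring nor the nitrile, with its hydrogen-bond acceptor, is needed at this carbon for a low number. The nine-carbon chain and cyclopentyl are separated by only a modest step, a 2.8-fold higher number from compound 1 to compound 4 (0.45 log units; beyond the scatter), which shows that the non-aromatic cyclopentyl ring stays close to the long chain, while the 2-(methylsulfanyl)ethyl chain does not, so a small group is not in itself what sets compound 2 apart. The gap to that compound is large, an at least 1700-fold lower number from compound 2 to compound 4 (3.25 log units; beyond the scatter), and the value of compound 2 is only a limit: the limit of > 10000 nM in this assay, at which 1 of the 4 values shown sits.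

From the compounds shown here alone, what remains open is whether the loss in compound 2 goes with its sulfur or with its short open chain, a question that a plain butyl chain at this carbon would address. Also open, going by these compounds, is how a cyclopentyl ring carrying a hydroxyl group, an amine or a carboxylic acid would read in this assay.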